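Swapping the alkyne tail for a hydroxyl-bearing chain

The source may hold more compounds than are shown below. What is called first, only, known or untested is meant among the compounds shown, and "the series" means these compounds.

Three brominated diaryl ethers sharing one core have been tested in a functional assay on U-937 cells (Homo sapiens) for cytotoxicity, read by MTT assay, with a stated time of 24 h; a lower number here means a stronger inhibitor, a higher number a weaker inhibitor. Compound 2 `C#CCOc1c(Br)cc(Br)cc1Oc1ccc(Br)cc1Br` gives 29.5 ug/mL. Compound 3 `BrCCCOc1c(Br)cc(Br)cc1Oc1ccc(Br)cc1Br` gives 30.3 ug/mL, and compound 1 `Brc1ccc(Oc2cc(Br)cc(Br)c2OCCCCCN2CCN(C/C=C/c3ccccc3)CC2)c(Br)c1`, which carries a much longer side chain, gives 32.7 ug/mL. Compound 2 thus stands with its number alongside those of compound 3 and compound 1, every gap between them within the scatter of repeated measurements, so none of the three can be called stronger or weaker than another.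

Compound 4 `OCCCOc1c(Br)cc(Br)cc1Oc1ccc(Br)cc1Br` differs from compound 2 by 2-hydroxyethyl in place of ethynyl on a saturated chain carbon bound to an oxygen on an aromatic ring. Going by the values given here, the one step that bears on this change is the earlier exchange of the same ethynyl for 2-bromoethyl at the same place, which gave a 1.0-fold higher number from compound 2 to compound 3 (0.01 log units; within the scatter). That precedent suggests the tail on this saturated chain carbon can be altered without any shift the assay can resolve. Compound 4 is therefore expected to give 30 ug/mL, with a range from 15 ug/mL to 60 ug/mL. The expected step is a 1.0-fold higher number from compound 2 to compound 4 (0.01 log units; within the scatter), a change within the scatter.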

Compound 4, half-maximal inhibitory concentration: 32.3 ug/mL
Compound 4: the middle estimate sits 1.1-fold (0.03 log units) below what was measured; low and high end bracket the measured number.
By their numbers in this assay, from the lowest: compounds 2, 3, 4 and 1 (each within the scatter of the next).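

In this assay, the tail on this saturated chain carbon now meets a different kind of change: 2-hydroxyethyl brings a hydrogen-bond donor and a hydrogen-bond acceptor that ethynyl lacks, yet the step is a 1.1-fold higher number from compound 2 to compound 4 (0.04 log units; within the scatter). Hydroxy in place of bromo at the end of the chain likewise gives a 1.1-fold higher number from compound 3 to compound 4 (0.03 log units; within the scatter), so ethynyl, 2-bromoethyl and 2-hydroxyethyl cannot be told apart at this position. No supporting data are available to explain why these numbers stay together.

As far as these compounds go, whether a carboxylic acid or an amide at the end of this chain would shift the number remains open. The compounds shown also include no tail that moves the number beyond the scatter, so it is unknown which kind of group, if any, would do so.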